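From methanesulfonamide to thiazole on the shared core

The compounds below may be only part of what the source reports. "The series", "measured", "known", "first", "only" and "open" are said of these compounds alone.

Compound 1 `c1cc(-c2ccn[nH]2)c2c(c1)C(c1ncc[nH]1)CC2` gives 336 nM in a functional assay on CHO cells for agonist activity at Alpha-1D adrenergic receptor (Homo sapiens), read by FLIPR and calcium flux; on this read-out higher numbers stand for an effect only at larger amounts of compound and lower numbers for an effect already at smaller amounts.
Compound 2 `Cn1ccc(-c2cccc3c2CCC3c2ncc[nH]2)n1` gives > 10000 nM in this assay.
Compound 3 `CS(=O)(=O)Nc1cccc2c1CCC2c1ncc[nH]1` gives > 10000 nM in this assay.

Compound 3 stands at the limit of > 10000 nM in this assay, at which 2 of the 3 values shown sit, so only a limit and no number is known for it. Compound 2 sits at the same limit. Only compound 1 carries a number, and both changes away from it were large: an at least 29-fold higher number from compound 1 to compound 2 (1.47 log units; beyond the scatter) and an at least 29-fold higher number from compound 1 to compound 3 (1.47 log units; beyond the scatter). The pair compound 2 and compound 3 cannot be read, as both are limits.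

Compound 4 `c1cc(-c2nccs2)c2c(c1)C(c1ncc[nH]1)CC2` differs from compound 3 by 1,3-thiazol-2-yl in place of methanesulfonamido on an aromatic carbon. The entering group, like the pyrazolyl groups of compound 1 and compound 2, is a five-membered aromatic ring, but like that of compound 2 it has no hydrogen-bond donor. The step is expected as an at least 3.3-fold lower number from compound 3 to compound 4 (0.52 log units; beyond the scatter), with a wide range. For compound 4 the estimate in this assay is 3000 nM, between 500 nM and 20000 nM.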

Compound 4, half-maximal effective concentration: 3190 nM
Compound 4: middle estimate off by 1.1-fold (0.03 log units), on the low side; low and high end bracket the measured number.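

Compound 4 gives a number where the 1-methyl-1H-pyrazol-3-yl and methanesulfonamido groups gave only a limit, so a five-membered aromatic ring with no hydrogen-bond donor at this aromatic carbon need not sit at that limit: the limit of > 10000 nM in this assay, at which 2 of the 4 values shown sit.

The 1,3-thiazol-2-yl group gives an at least 3.1-fold lower number from compound 2 to compound 4 (0.49 log units; beyond the scatter) and an at least 3.1-fold lower number from compound 3 to compound 4 (0.49 log units; beyond the scatter). It still falls short of the 1H-pyrazol-5-yl group, with a 9.5-fold higher number from compound 1 to compound 4 (0.98 log units; beyond the scatter).

Whether the hydrogen-bond donor of the 1H-pyrazol-5-yl group accounts for that gap remains open. From the compounds shown here alone, how a phenyl ring, an amine or a carboxylic acid would read at this aromatic carbon is also open.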